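The compounds below may be only part of what the source reports. "The series", "measured", "known", "first", "only" and "open" are said of these compounds alone.

Compound 1 has the structure `CCC(=O)Nc1ncc(-c2ccc(OC)cc2)n1C`. In a toxicity assay on THP-1 cells (Homo sapiens) for inhibition (on this read-out higher numbers stand for lower toxicity in this test and lower numbers for higher toxicity in this test), compound 1 gives only a limit, > 100000 nM. Compound 2 has the structure `COc1ccc(-c2cnc(NC(=O)c3ccc([N+](=O)[O-])cc3)n2C)cc1`. In this assay compound 2 likewise gives only a limit, > 100000 nM.

Both measured compounds therefore stand at the same place in this assay: the limit of > 100000 nM in this assay, at which 2 of the 2 values shown sit. Neither shows measurable toxicity within the tested range, and the two values show no difference between them.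

Compound 3 has the structure `COc1ccc(-c2cnc(NC(=O)c3ccc(Cl)cc3)n2C)cc1` and has not yet been tested in this assay. It arises from compound 2 by the change (chloro in place of nitro on an aromatic carbon). For the measured compounds named here, no measured step between compound 2 and compound 3 exists, so the size of the step can only be expected. Since compound 2 gives a limit in this assay and compound 1 gives a limit too, the replacement of one small para group by another is expected to leave the read-out near the limit, with an expected step of a number no higher from compound 2 to compound 3 (the limit leaves the size open) in this assay, that is, none beyond the scatter. Compound 3 is estimated at 100000 nM in this assay, within a range from 30000 nM to 300000 nM.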

Compound 3, half-maximal cytotoxic concentration: > 100000 nM
Compound 3: only a limit was reported (the forecaster's own chance of this, stated with the estimate: 80%); the middle value lies on the limit itself.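

Compound 3, like compound 1 and compound 2, gives only a limit in this assay, so neither the step from compound 2 to compound 3 nor the step from compound 1 to compound 3 can be read: the limit of > 100000 nM in this assay, at which 3 of the 3 values shown sit.

The compounds shown leave open how far apart the three lie in this assay, and whether any group on the carbonyl carbon would give a measurable value.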